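The source may hold more compounds than are shown below. What is called first, only, known or untested is meant among the compounds shown, and "the series" means these compounds.

Compound 1 `CCCOCC1=CS(=O)(=O)c2ccccc2C1=O` is measured in a functional assay on the whole organism for inhibition, with Mus musculus as the target, at a dose of 10 mg/kg (on this read-out higher numbers stand for more inhibition at the one dose given (going by the name of the read-out) and lower numbers for less inhibition), at 99.9%, the highest of the three numbers in hand. Compound 2 `CC(C)OCC1=CS(=O)(=O)c2ccccc2C1=O` gives 99.2% in this assay, and the step of a number 0.7 percentage points lower from compound 1 to compound 2 (within the scatter) is within the scatter. Compound 3 `O=C1C(COCCCl)=CS(=O)(=O)c2ccccc21` gives 98.1%, with the step of a number 1.8 percentage points lower from compound 1 to compound 3 (within the scatter) also within the scatter, as is the step of a number 1.1 percentage points lower from compound 2 to compound 3 (within the scatter). Compound 4 `CC(=O)OCC1=CS(=O)(=O)c2ccccc2C1=O` is not yet measured; it differs from compound 1 in one place: acetyl in place of propyl on an oxygen on a saturated carbon. Among the compounds with values here, the steps that bear on it are the two that also change the group on this oxygen, from compound 1 to compound 2 and from compound 2 to compound 3, and neither moved this assay beyond the scatter. Compound 4 is therefore expected near compound 1, at an estimated 97%, within 86% to 100%, and the expected step is a number 2.9 percentage points lower from compound 1 to compound 4 (within the scatter).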

Compound 4, a percentage reported as inhibition, in the whole organism at one dose (the size of the read-out at that dose, not a potency): 99.5%
Beside the measured number, compound 4's estimate is 2.5 percentage points below it; low and high end bracket the measured number.
By their numbers in this assay, from the lowest: compounds 3, 2, 4 and 1 (each within the scatter of the next).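

Until now this oxygen had carried only saturated groups; acetyl adds a double bond and a hydrogen-bond acceptor, yet in this assay the result is a number 0.4 percentage points lower from compound 1 to compound 4 (within the scatter), a number 0.3 percentage points higher from compound 2 to compound 4 (within the scatter) and a number 1.4 percentage points higher from compound 3 to compound 4 (within the scatter). The read-out at this dose therefore does not separate acetyl from the saturated groups at this position. Nothing at hand explains this result.

From the compounds shown here alone, whether an amine, a carboxylic acid or a longer chain on this oxygen would give a similar number remains open. Going by these compounds, with all four compounds this close at a single dose, their relative potency also remains open.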